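From 3-bromophenyl to 4-methylphenyl

A few compounds are considered here, and "the series" means these few. Any claim that something is new, unique, unknown or untested is made for them only; others in the source may bear on it.

Measured so far in a functional assay on HCT-116 cells (Homo sapiens) for antiproliferative activity, read by MTT assay, with a stated time of 72 h (on this read-out lower numbers stand for stronger inhibition and higher numbers for weaker inhibition), are these values
compound 1 `NC1=NC2(CCOCC2)N(OCCCOc2ccccc2Cl)C(N)=N1` at 70 nM
compound 2 `NC1=NC2(CCOCC2)N(OCCCOc2ccc(Cl)c(Cl)c2)C(N)=N1` at 90 nM
compound 3 `NC1=NC2(CCOCC2)N(OCCCOc2cccc(Br)c2)C(N)=N1` at 40 nM

Compound 3 stands at 40 nM in this short series. Its nearest measured step is a 1.8-fold lower number from compound 1 to compound 3 (0.24 log units; within the scatter) and its furthest is a 2.3-fold lower number from compound 2 to compound 3 (0.35 log units; beyond the scatter) in a modest move.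

Compound 4 `Cc1ccc(OCCCON2C(N)=NC(N)=NC23CCOCC3)cc1` has not yet been measured. It carries 4-methylphenyl in place of 3-bromophenyl on an oxygen on a saturated carbon and keeps everything else unchanged.

Among the compounds with values here, the steps that bear on this change are the exchanges at that same place. Besides the two above, they include a 1.3-fold higher number from compound 1 to compound 2 (0.11 log units; within the scatter) as the third. Within the data shown here, none of the measured compounds carries 4-methylphenyl, so these steps give only a rough guide to size. The expected step is a 1.8-fold higher number from compound 3 to compound 4 (0.24 log units; within the scatter) and no larger move is anticipated. In this assay the value expected for compound 4 is estimated at 70 nM, within an expected range of 30 nM to 170 nM.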

Compound 4, half-maximal inhibitory concentration: 2390 nM
For compound 4 the middle estimate is 34-fold (1.53 log units) below the measured one, and the stated range ends below it.
By their numbers in this assay, from the lowest: compounds 3, 1 and 2 (each within the scatter of the next, the first and the last beyond it); then compound 4.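

In this assay, within the data shown here, the group on this oxygen proves far less open to exchange than the earlier compounds suggested: the largest step among them was a 2.3-fold lower number from compound 2 to compound 3 (0.35 log units; beyond the scatter) and yet 4-methylphenyl brings a 60-fold higher number from compound 3 to compound 4 (1.78 log units; beyond the scatter) together with a 27-fold higher number from compound 2 to compound 4 (1.42 log units; beyond the scatter) and a 34-fold higher number from compound 1 to compound 4 (1.53 log units; beyond the scatter) in a single change. Compound 4 is the only one of the four whose aryl group carries no halogen, so the three halogen-bearing groups no longer stand for the whole range at this place. Nothing at hand explains the size of this loss.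

Compound 4 differs from compound 3 in both the substituent and its place on the ring, so the compounds shown cannot separate these two changes. A 3-methylphenyl or a 4-bromophenyl group would pull them apart, and a plain phenyl group would show where the bare ring stands.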